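The compounds below may be only part of what the source reports. "The series", "measured", "known", "first", "only" and "open" are said of these compounds alone.

Compound 1 `CC(Oc1cccnc1Nc1cnn(C)c1)c1cccc(C(=O)NCc2ccccc2S(=O)(=O)C(C)C)c1` and compound 2 `Cc1ccc(CNC(=O)c2cccc(C(C)Oc3cccnc3Nc3ncccn3)c2)cc1` share a core but differ in several places, so only their two values can be set side by side. In a functional assay on HCC78 cells (Homo sapiens) for antiproliferative activity, read by MTT assay, with a stated time of 48 h (a lower number here means a stronger inhibitor, a higher number a weaker inhibitor), compound 1 gives 63100 nM. Compound 2 stands at the assay limit, > 100000 nM, and no number is known for it; this is the limit of > 100000 nM in this assay, at which 1 of the 2 values shown sits. Compound 3 `Cc1ccc(CNC(=O)c2cccc(C(C)Oc3cccnc3Nc3cnn(CC#N)c3)c2)cc1` carries 1-(cyanomethyl)-1H-pyrazol-4-yl in place of pyrimidin-2-yl on a nitrogen on an aromatic ring. Compound 1 also bears a pyrazolyl group on that nitrogen, so a measurable value is expected for compound 3, near 60000 nM with a range of 20000 nM to 100000 nM. The expected shift an at least 1.6-fold lower number from compound 2 to compound 3 (0.22 log units; that floor lies within the scatter) cannot be sized against a limit.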

Compound 3, half-maximal inhibitory concentration: 57400 nM
Compound 3: the middle estimate sits 1.0-fold (0.02 log units) above what was measured; measured number inside the range.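

With 1-(cyanomethyl)-1H-pyrazol-4-yl in place of pyrimidin-2-yl on a nitrogen on an aromatic ring, this assay now gives a step on this position: an at least 1.7-fold lower number from compound 2 to compound 3 (0.24 log units; that floor lies within the scatter). Compound 2 is a limit and not a number: the limit of > 100000 nM in this assay, at which 1 of the 3 values shown sits. On these data alone, the step is therefore only a floor, and its true size remains unknown.

As far as these compounds go, the contribution of the cyanomethyl group apart from the pyrazole ring remains open. A pyrazolyl group carrying a hydroxyethyl chain or an amine in its place would separate the two.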